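Capping the hydroxy group of compound 1 with methyl

The source may hold more compounds than are shown below. What is called first, only, known or untested is meant among the compounds shown, and "the series" means these compounds.

Measured in an ADME assay on MT4 cells (Homo sapiens) for cytotoxicity, read by MTT assay, with a stated time of 4 days; on this read-out lower numbers stand for higher toxicity in this test and higher numbers for lower toxicity in this test:
- compound 1 `COc1ccc(-c2oc3ccc(N)cc3c(=O)c2O)cc1`: 239000 nM
- compound 2 `Nc1ccc2oc(-c3ccc(F)cc3)c(O)c(=O)c2c1`: 92600 nM
- compound 3 `Nc1ccc2oc(-c3ccc(C(F)(F)F)cc3)c(O)c(=O)c2c1`: 3900 nM

Compound 1 has the highest number of the three, so it is the least toxic in this assay, and both other compounds lie beyond the scatter from it. The next compound, compound 4 `COc1ccc(-c2oc3ccc(N)cc3c(=O)c2OC)cc1`, keeps the core of compound 1 and changes one spot: methyl in place of hydrogen on an oxygen on an aromatic ring. In other words, a hydroxy becomes a methoxy.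

The measured steps all swap a group on an aromatic carbon. They are a 2.6-fold lower number from compound 1 to compound 2 (0.41 log units; beyond the scatter), a 61-fold lower number from compound 1 to compound 3 (1.79 log units; beyond the scatter) and a 24-fold lower number from compound 2 to compound 3 (1.38 log units; beyond the scatter). These steps show that the numbers can move a long way within this small set, but none of them alters the hydroxy group. They therefore give no direct guide to this change, and no step beyond the scatter is expected with any confidence. Only a slight lean towards a lower number is assumed, since compound 1 sits at the top with 239000 nM.

The estimated step is a 1.6-fold lower number from compound 1 to compound 4 (0.20 log units; within the scatter).

For compound 4 the expected value is 150000 nM, with an estimated range from 40000 nM to 400000 nM.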

Compound 4, half-maximal cytotoxic concentration: 200000 nM
Estimate against measurement, compound 4: 1.3-fold (0.12 log units) below, within the range that was stated.
By their numbers in this assay, from the lowest: compound 3; then compound 2; then compounds 4 and 1 (each within the scatter of the next).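

Methoxy in place of hydroxy is the only change shown at this oxygen, and in this assay it gives a 1.2-fold lower number from compound 1 to compound 4 (0.08 log units; within the scatter) in a step that stays within the usual scatter of repeated measurements. The swaps on an aromatic carbon moved the number beyond the scatter, but this change leaves no readable difference, so in this test the hydrogen on this oxygen can be replaced by methyl without a measurable shift. No measured information accompanies these compounds that would explain this result.

From the compounds shown here alone, whether a longer chain such as ethyl or an acetyl group on this oxygen would also leave the number unchanged remains open. Going by these compounds, it is equally open whether the same capping would give so small a step on compound 3, which carries trifluoromethyl.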